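A few compounds are considered here, and "the series" means these few. Any claim that something is new, unique, unknown or untested is made for them only; others in the source may bear on it.

Compound 1 `CN(C)CCn1cnnc1-c1cc(Oc2ccc(NC(=O)N/N=C/c3cccc(Br)c3)cc2F)ccn1` gives 970 nM in a functional assay on A549 cells (Homo sapiens) for cytotoxicity, read by MTT assay, with a stated time of 72 h; a lower number here means a stronger inhibitor, a higher number a weaker inhibitor.
Compound 2 `CN(C)CCn1cnnc1-c1cc(Oc2ccc(NC(=O)N/N=C/c3cc(C(C)(C)C)cc(C(C)(C)C)c3O)cc2F)ccn1` gives 980 nM in this assay.
Compound 3 `CN(C)CCn1cnnc1-c1cc(Oc2ccc(NC(=O)N/N=C/c3ccc(O)c(Br)c3)cc2F)ccn1` gives 1370 nM in this assay.

Compound 3 carries the highest of the three numbers, but both compound 2 and compound 1 lie within the scatter of it, so no order can be read among the three. Compound 4 `COc1cc(/C=N/NC(=O)Nc2ccc(Oc3ccnc(-c4nncn4CCN(C)C)c3)c(F)c2)cc(OC)c1OC` differs from compound 3 in one place: 3,4,5-trimethoxyphenyl in place of 3-bromo-4-hydroxyphenyl on a carbon with a double bond to nitrogen. Among the compounds with values here, the only measured step touching this place is a 1.4-fold higher number from compound 1 to compound 3 (0.15 log units; within the scatter), which concerns the hydroxy alone; no measured step swaps the whole aryl group, though compounds 1 and 2 show two rather different groups there giving numbers within the scatter of each other. A step within the scatter is therefore expected, a 1.1-fold lower number from compound 3 to compound 4 (0.02 log units; within the scatter). Compound 4 is estimated at 1300 nM, between 500 nM and 3500 nM.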

Compound 4, half-maximal inhibitory concentration: > 100000 nM
Compound 4 gave a limit, no number (the forecaster's own chance of this, stated with the estimate: 5%); middle value at least 76-fold (1.88 log units) from the limit.
By their numbers in this assay, from the lowest: compounds 1, 2 and 3 (each within the scatter of the next). At a limit, above all of these: compound 4.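

In this assay, compound 4 reads as a limit, not a number: the limit of > 100000 nM in this assay, at which 1 of the 4 values shown sits.

The aryl group on the carbon with a double bond to nitrogen is therefore not freely exchangeable, although the earlier swaps there stayed within the scatter. 3,4,5-Trimethoxyphenyl gives an at least 72-fold higher number from compound 3 to compound 4 (1.86 log units; beyond the scatter) and an at least 100-fold higher number from compound 1 to compound 4 (2.01 log units; beyond the scatter).

The compounds shown do not separate the loss of bromine from the entry of the three methoxy groups. From the compounds shown here alone, whether a phenyl carrying a single methoxy, an amine or a carboxylic acid keeps the activity of compound 1 remains open.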